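Amide substituent variation in a bromo-iminochromene carboxamide series

The source may report more compounds than this note shows. Statements on the series, on what has been measured and on what is new or still open speak of the compounds shown alone.

Measured compounds:
compound 1 `N=c1oc2ccc(Br)cc2cc1C(=O)NCCO` — 26%
compound 2 `CCC(CO)NC(=O)c1cc2cc(Br)ccc2oc1=N` — 20%
compound 3 `N=c1oc2ccc(Br)cc2cc1C(=O)NC1CCCC1` — 17%

Three analogues sharing one core differ only in the group on the amide-type nitrogen. In an assay on CHO cells for displacement of a labelled ligand from adenosine receptor A1 (Homo sapiens), read by scintillation counting, with a stated time of 60 min, tested at 10 uM (on this read-out higher numbers stand for more inhibition at the one concentration tested (going by the name of the read-out) and lower numbers for less inhibition), compound 1 gives 26%, compound 2 gives 20% and compound 3 gives 17%. Compound 3 holds the lowest of the three numbers, but the gaps a number 9 percentage points lower from compound 1 to compound 3 (within the scatter) and a number 3 percentage points lower from compound 2 to compound 3 (within the scatter) are both within the scatter, so the three read as equivalent.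

Compound 4 `N=c1oc2ccc(Br)cc2cc1C(=O)NCCCO` is the next analogue. Its change from compound 3:
3-hydroxypropyl in place of cyclopentyl on an amide-type nitrogen

Among the compounds with values here, the step of a number 9 percentage points lower from compound 1 to compound 3 (within the scatter) is the closest precedent, an exchange of cyclopentyl against a hydroxyalkyl chain that stayed within the scatter; a number 3 percentage points lower from compound 2 to compound 3 (within the scatter) points the same way. No change beyond the scatter is therefore expected in this assay, with a number 7 percentage points higher from compound 3 to compound 4 (within the scatter) as the expected step. Compound 4 is estimated at 24%, range 10% to 38%.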

Compound 4, a percentage reported as inhibition, at one concentration (the size of the read-out at that concentration, not a potency): 32%
The estimate for compound 4 lay 8 percentage points below the measured number; low and high end bracket the measured number.
By their numbers in this assay, from the lowest: compounds 3, 2, 1 and 4 (each within the scatter of the next, the first and the last beyond it).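

In this assay, within the data shown here, the group on the amide-type nitrogen now gives steps beyond the scatter, with a number 15 percentage points higher from compound 3 to compound 4 (beyond the scatter) and a number 12 percentage points higher from compound 2 to compound 4 (beyond the scatter), both modest, where no step among the earlier compounds left it. 3-Hydroxypropyl therefore separates from cyclopentyl and from 1-(hydroxymethyl)propyl at this position, though only by a modest margin at the one concentration tested. With a number 6 percentage points higher from compound 1 to compound 4 (within the scatter), 3-hydroxypropyl stays unresolved from the 2-hydroxyethyl of compound 1, so the added chain carbon has no readable effect.

Open, going by these compounds, is whether a plain propyl chain keeps the gain without the hydroxy, and whether a longer chain such as 4-hydroxybutyl, or an amine or carboxylic acid in place of the hydroxy, moves the number further. No measured evidence bears on what lies behind these steps.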